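This account rests on a few compounds, and the source may have more. Where it says the series, first, only, none or still open, it means among the compounds named here.

Measured so far in an assay on HEK293 cells for positive allosteric modulation of metabotropic glutamate receptor 5 (Homo sapiens), read by FLIPR; on this read-out lower numbers stand for an effect already at smaller amounts and higher numbers for an effect only at larger amounts of compound:

Compound 1 `O=C(N1CCCCC1)N1CC(c2nc(-c3cccc(Cl)c3)no2)C1` gives 370 nM.
Compound 2 `O=S(=O)(c1ccc(F)cc1)N1CC(c2nc(-c3cccc(Cl)c3)no2)C1` gives only a limit of the assay, > 10000 nM.
Compound 3 `Cc1cccc(-c2noc(C3CN(S(=O)(=O)c4ccc(Cl)cc4)C3)n2)c1` likewise gives only a limit of the assay, > 10000 nM.

Compound 1 therefore stands alone: it is the only one of the three with a number in this assay, the other two sitting at the limit of > 10000 nM in this assay, at which 2 of the 3 values shown sit. For the measured compounds named here, no two measured compounds differ in a single place, so no measured step sets a scale for what a change at the carbonyl carbon does.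

Compound 4 `O=C([C@@H]1CC2CCC1C2)N1CC(c2nc(-c3cccc(Cl)c3)no2)C1` is next to be measured. It differs from compound 1 as follows: a group of 7 heavy atoms (7 carbon; 2 five-membered non-aromatic rings of carbon only) in place of a group of 6 heavy atoms (5 carbon, 1 nitrogen; one six-membered non-aromatic ring with 1 hetero atom), on a carbonyl carbon. The carbonyl on the amide-type nitrogen in a ring is kept, so the change is confined to the group carried on that carbonyl carbon.

Going by the values given here, with no measured step to lean on, the expectation for compound 4 is a step of a 1.1-fold higher number from compound 1 to compound 4 (0.03 log units; within the scatter), that is, none beyond the usual scatter. Compound 4 is estimated at 400 nM, with a range from 120 nM to 1300 nM. A limit rather than a number is considered unlikely for compound 4.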

Compound 4, half-maximal effective concentration: 98 nM
Compound 4: the middle estimate sits 4.1-fold (0.61 log units) above what was measured, outside the stated range (below it).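

In this assay, the group on the carbonyl carbon is now seen to move the read-out: the change from piperidin-1-yl to the all-carbon group with two five-membered rings gives a 3.8-fold lower number from compound 1 to compound 4 (0.58 log units; beyond the scatter). This position therefore does not need the ring nitrogen of compound 1, at least with the carbonyl on the amide-type nitrogen in a ring kept. Nothing at hand accounts for the size of this step.

On these data alone, compound 4 changes the ring nitrogen, the ring system and the defined stereocentre all at once, so their separate contributions remain open. A cyclohexyl group on the same carbonyl carbon would separate the loss of the nitrogen from the change in ring system, and the opposite configuration at the stereocentre remains an open question.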